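A few compounds are considered here, and "the series" means these few. Any claim that something is new, unique, unknown or untested is made for them only; others in the source may bear on it.

Three compounds share one core and differ only in the five-membered ring attached to it. Compound 1 `Cn1cccc1-c1ncnc2c1ncn2C1O[C@H](CO)[C@@H](O)[C@H]1O` carries a 1-methyl-1H-pyrrol-2-yl group, compound 2 `OC[C@H]1OC(n2cnc3c(-c4ccco4)ncnc32)[C@H](O)[C@@H]1O` a furan-2-yl group and compound 3 `OC[C@H]1OC(n2cnc3c(-c4ccoc4)ncnc32)[C@H](O)[C@@H]1O` a furan-3-yl group. In a functional assay on HL-60 cells (Homo sapiens) for inhibition (on this read-out higher numbers stand for weaker inhibition and lower numbers for stronger inhibition), compound 1 gives 15700 nM, compound 2 gives 2700 nM and compound 3 gives 3300 nM. Compound 2 has the lowest number of the three, yet its gap to compound 3 lies within the scatter, whereas a 5.8-fold lower number from compound 1 to compound 2 (0.76 log units; beyond the scatter) and a 4.8-fold lower number from compound 1 to compound 3 (0.68 log units; beyond the scatter) are both beyond it. Compound 4 `OC[C@H]1OC(n2cnc3c(-c4ccsc4)ncnc32)[C@H](O)[C@@H]1O` has not been measured and differs from compound 2 in one place: thiophen-3-yl in place of furan-2-yl on an aromatic carbon. The step that bears most directly on this change is a 1.2-fold higher number from compound 2 to compound 3 (0.09 log units; within the scatter), which shows that moving the attachment point of the furan ring hardly matters. For the measured compounds named here, no measured pair replaces a furan ring with a thiophene ring, so that part of the change is untested. For compound 4 a step of about a 1.1-fold lower number from compound 2 to compound 4 (0.03 log units; within the scatter) is expected, which is within the scatter. Compound 4 is therefore estimated at 2500 nM, with a range from 900 nM to 7000 nM.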

Compound 4, half-maximal inhibitory concentration: 3800 nM
Estimate against measurement, compound 4: 1.5-fold (0.18 log units) below; low and high end bracket the measured number.
By their numbers in this assay, from the lowest: compounds 2, 3 and 4 (each within the scatter of the next); then compound 1.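

Sulfur can take the place of the ring oxygen at this carbon with no shift beyond the scatter in this assay: a 1.4-fold higher number from compound 2 to compound 4 (0.15 log units; within the scatter) and a 1.2-fold higher number from compound 3 to compound 4 (0.06 log units; within the scatter) are both within it, and the second is the cleaner comparison, since the ring stays attached through the same ring position. Compound 1 remains apart from the new ring too, with a 4.1-fold lower number from compound 1 to compound 4 (0.62 log units; beyond the scatter) as the step, so among these four compounds only the 1-methyl-1H-pyrrol-2-yl group separates from the others. Nothing available here explains why the rings group this way.

As far as these compounds go, it remains open whether the methyl group or the ring nitrogen of compound 1 accounts for its separate place. Also open, from the compounds shown here alone, is how a six-membered phenyl ring, an amine or a longer alkyl chain on this carbon would compare with the furan and thiophene rings.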